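Moving the methyl group from compound 3 to compound 4

The source may hold more compounds than are shown below. What is called first, only, known or untested is meant among the compounds shown, and "the series" means these compounds.

Measured in an ADME assay on microsomes from liver (Rattus norvegicus) for metabolic stability, read by LC-MS, using NADPH, at 37 degrees C (a higher number here means that the compound lasts longer, a lower number that the compound disappears faster), so far:
Compound 1 `Cc1oc(-c2ccccc2Cl)nc1CN1CCC(C(=O)NCCCN2C[C@H](C)C[C@H](C)C2)CC1` gives 0.25 h
Compound 2 `Cc1oc(-c2c(Cl)cccc2Cl)nc1CN1CCC(C(=O)NCCCN2C[C@H](C)C[C@H](C)C2)CC1` gives 0.0483 h
Compound 3 `Cc1cccc(-c2nc(CN3CCC(C(=O)NCCCN4C[C@H](C)C[C@H](C)C4)CC3)c(C)o2)c1` gives > 0.5 h as a limit, not a number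

Compound 3 stands at the limit of > 0.5 h in this assay, at which 1 of the 3 values shown sits, and so has no exact value. Compound 4 `Cc1ccc(-c2nc(CN3CCC(C(=O)NCCCN4C[C@H](C)C[C@H](C)C4)CC3)c(C)o2)cc1` has not yet been measured. It differs from compound 3 by 4-methylphenyl in place of 3-methylphenyl on an aromatic carbon with 4-methylphenyl in place of 3-methylphenyl on an aromatic carbon.

For the measured compounds named here, no measured step moves a methyl group, so the evidence is indirect. There is an at least 10-fold higher number from compound 2 to compound 3 (1.01 log units; beyond the scatter) and there is an at least 2.0-fold higher number from compound 1 to compound 3 (0.30 log units; that floor lies within the scatter) and in both a chlorinated phenyl group leaves while 3-methylphenyl enters. The chloro change itself appears as a 5.2-fold lower number from compound 1 to compound 2 (0.71 log units; beyond the scatter) and no chloro enters in compound 4. No step beyond the scatter is therefore expected in this assay in either direction. The estimate amounts to an at least 1.1-fold lower number from compound 3 to compound 4 (0.04 log units; that floor lies within the scatter) and this expected step is small. The expected value for compound 4 is 0.45 h with an estimated range from 0.2 h to 0.7 h. There is a fair chance that compound 4 will give only a limit.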

Compound 4, half-life: > 0.5 h
Compound 4: a limit, no number (the forecaster's own chance of this, stated with the estimate: 45%); middle value at least 1.1-fold (0.04 log units) away from the limit.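

In this assay compound 4, with 4-methylphenyl in place of 3-methylphenyl, gives > 0.5 h, which is a limit and not a number. Set against the chlorinated compounds, there is an at least 10-fold higher number from compound 2 to compound 4 (1.01 log units; beyond the scatter) and there is an at least 2.0-fold higher number from compound 1 to compound 4 (0.30 log units; that floor lies within the scatter), so a second methylphenyl group now stands with compound 3 in this comparison, clearly apart from compound 2 but not clearly apart from compound 1. The step between compound 3 and compound 4 cannot be read, as both compounds rest on the same limit: the limit of > 0.5 h in this assay, at which 2 of the 4 values shown sit.

As far as these compounds go, it therefore stays open whether moving the methyl group changes the half-life at all. Also open, from the compounds shown here alone, is how a methoxy group or a nitrile would fare on this phenyl ring in place of the methyl group.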